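Fluoro Added Beside the Amide: An Expected Step

A few compounds are considered here, and "the series" means these few. Any claim that something is new, unique, unknown or untested is made for them only; others in the source may bear on it.

Compound 1 `O=C(Nc1ccc(Oc2ccnc3[nH]ccc23)c(F)c1)c1nn(-c2ccc(Cl)cc2)ccc1=O` gives > 60000 nM, a limit of the assay. Compound 2 `O=C(Nc1ccc(Oc2ccnc3[nH]ccc23)c(F)c1)c1nn(-c2ccc(Cl)c(F)c2)ccc1=O` gives 9610 nM. Compound 3 `Cc1cc(=O)n(-c2ccc(F)cc2)nc1C(=O)Nc1ccc(Oc2ncnc3[nH]ccc23)cc1` gives > 60000 nM, a limit of the assay.

These values come from a functional assay on HepG2 cells (Homo sapiens) for cytotoxicity, read by MTT assay, with a stated time of 72 h; on this read-out higher numbers stand for weaker inhibition and lower numbers for stronger inhibition. Among the measured compounds shown here, the only counted step among the measured compounds is an at least 6.2-fold lower number from compound 1 to compound 2 (0.79 log units; beyond the scatter), and the change behind it is fluoro in place of hydrogen on an aromatic carbon. Whether the same kind of change works the same way on a different core is the question raised by compound 4 `Cc1cc(=O)n(-c2ccc(F)cc2)nc1C(=O)Nc1ccc(Oc2ncnc3[nH]ccc23)c(F)c1`, which is not yet measured in this assay. It differs from compound 3 by fluoro in place of hydrogen on an aromatic carbon. The difference between the core of compound 3 and the core of compound 1 is not broken down here. The two changes are the same kind of change, not the same: in compound 2 the entering fluoro sits ortho to a chloro group, while in compound 4 it sits ortho to a large group.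

For the measured compounds named here, for the measured step, the only point of evidence is the limit of > 60000 nM in this assay, at which 2 of the 3 values shown sit, so the size of the change from compound 1 to compound 2 is itself known only as a bound. Compound 3 sits at that same limit, so the step to compound 4 is expected to be an at least 1.5-fold lower number from compound 3 to compound 4 (0.17 log units; that floor lies within the scatter), resting on the shown change from compound 1 to compound 2 an at least 6.2-fold lower number from compound 1 to compound 2 (0.79 log units; beyond the scatter). Compound 4 is therefore estimated to come out near 40000 nM, within a range from 8000 nM to 100000 nM, with a real chance that the assay again reports only a limit.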

Compound 4, half-maximal inhibitory concentration: 12900 nM
Estimate against measurement, compound 4: 3.1-fold (0.49 log units) above; low and high end bracket the measured number.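

In this assay, fluoro in place of hydrogen on an aromatic carbon again came with a lower number when carried to the core of compound 3, giving an at least 4.6-fold lower number from compound 3 to compound 4 (0.66 log units; beyond the scatter). Set beside the earlier step, the change therefore points the same way on both cores, and each step lies beyond the usual scatter: the same change on two cores in this assay, an at least 6.2-fold lower number (0.79 log units; beyond the scatter) from compound 1 to compound 2 and an at least 4.6-fold lower number (0.66 log units; beyond the scatter) from compound 3 to compound 4; the limit leaves it open whether they differ Two cores show only a shared direction, not a shared size, and they say nothing about how the change would behave on a third core, since both steps start from a limit rather than a number: the limit of > 60000 nM in this assay, at which 2 of the 4 values shown sit.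

The compounds shown leave open whether another small group on the same aromatic carbon, such as a chloro group, a methoxy group or an amine, would go with a similar step on either core, or whether the step belongs to fluoro alone. They also leave open whether the step would persist if the methyl group of compound 4 gave way to a longer chain or a carboxylic acid, and how far the lower numbers seen with these HepG2 cells would extend to any other read-out.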